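This account rests on a few compounds, and the source may have more. Where it says the series, first, only, none or still open, it means among the compounds named here.

In an ADME assay on liver for metabolic stability, with Liver microsome (Homo sapiens) as the target, using microsomes (a higher number here means faster removal of the compound, a lower number slower removal), compound 1 `CCN(CC)CCN(C)c1ccc(Nc2cc(NC3CC3)n3ncc(C#N)c3n2)cc1NC(C)=O` gives 44 mL.min-1.g-1. Compound 2 `CC(=O)Nc1cc(Nc2cc(NC3CC3)n3ncc(C#N)c3n2)ccc1N1CCC[C@H](N)C1` gives < 3 mL.min-1.g-1, which is a limit of the assay and not a number. Compound 3 `CC(=O)Nc1cc(Nc2cc(NC3CC3)n3ncc(C#N)c3n2)ccc1N1CCC[C@@H](N)C1` differs from compound 2 in this way: the two compounds have the same atoms and bonds and differ only in configuration as drawn: 1 of 1 stereo elements differ; a stereocentre at a saturated ring carbon is drawn S in compound 2 and R in compound 3. Within the data shown here, the only measured step, an at least 14-fold lower number from compound 1 to compound 2 (1.16 log units; beyond the scatter), is large, but it puts 3-aminopiperidin-1-yl in place of (2-(diethylamino)ethyl)(methyl)amino and does not test configuration. Compound 3 keeps the 3-aminopiperidin-1-yl group. The step of a number no lower from compound 2 to compound 3 (the limit leaves the size open) is therefore expected to stay within the scatter in this assay, with no direction assumed. Compound 3 is estimated at 3 mL.min-1.g-1, with an expected range of 1.5 mL.min-1.g-1 to 9 mL.min-1.g-1.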

Compound 3, intrinsic clearance in microsomes in the Liver microsome assay: < 3 mL.min-1.g-1
Compound 3: no number, only a limit; the forecaster's own chance of this, stated with the estimate: 60%; the middle value lies on the limit itself.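

In the Liver microsome assay, the 3-aminopiperidin-1-yl group drawn R gives an at least 14-fold lower number from compound 1 to compound 3 (1.16 log units; beyond the scatter), so the large step seen with the S form also holds with the other configuration. The step between compound 2 and compound 3 cannot be read in this assay, because both sit at a limit: the limit of < 3 mL.min-1.g-1 in the Liver microsome assay, at which 2 of the 3 values shown sit. In a physicochemical assay for solubility, read by LC-MS, in phosphate buffer, with a stated time of 24 h, at pH 7.4 (a lower number here means a less soluble compound, a higher number a more soluble compound), compound 2 gives 704000 nM. In the physicochemical assay compound 3 gives > 1000000 nM, which is a limit of the assay and not a number. In the physicochemical assay the printed step, an at least 1.4-fold higher number from compound 2 to compound 3 (0.15 log units; that floor lies within the scatter), rests on this limit for compound 3: the limit of > 1000000 nM in the physicochemical assay, at which 1 of the 2 values shown sits.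

Still open, as far as these compounds go, is whether the two configurations differ in the Liver microsome assay once a number can be read. Also open, from the compounds shown here alone, is whether the low clearance holds with a hydroxyl or dimethylamino group in place of the amino group of 3-aminopiperidin-1-yl.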